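The compounds below may be only part of what the source reports. "The series", "measured", "known", "first", "only" and "open" are said of these compounds alone.

Measured compounds:
- compound 1 `COc1ccc(/C=C2/N=C(c3ccccc3)N(C(=O)c3ccc(Cl)cc3)NC2=O)cc1`: 100 mg/kg
- compound 2 `Cc1ccc(C(=O)N2NC(=O)/C(=C\c3ccc(O)cc3)N=C2c2ccccc2)cc1`: 100 mg/kg
- compound 3 `Cc1ccc(/C=C2/N=C(c3ccccc3)N(C(=O)c3ccc(C)cc3)NC2=O)cc1`: 30 mg/kg

In a functional assay on the whole organism (strain albino) with Mus musculus as the target, with a stated time of 0.5 h (on this read-out lower numbers stand for an effect already at smaller amounts and higher numbers for an effect only at larger amounts of compound), compound 3 gives the lowest number of the three. Its nearest neighbour is compound 1 and compound 2 sits at the same distance; both steps lie beyond the scatter. Compound 4 `COc1ccc(/C=C2/N=C(c3ccccc3)N(C(=O)c3ccc(C)cc3)NC2=O)cc1` is not yet measured. It differs from compound 3 by methoxy in place of methyl on an aromatic carbon, with the acyl group on the shared core unchanged.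

Among the compounds with values here, only one measured step touches this position: a 3.3-fold lower number from compound 2 to compound 3 (0.52 log units; beyond the scatter), a change from hydroxy to methyl at the same carbon. The reverse direction, from methyl toward an oxygen-bearing group, thus points to a higher number. Within the data shown here, compound 1 carries the same methoxy as compound 4 but a different acyl group, and in this assay compound 1 gives 100 mg/kg; no single-point step between compound 1 and compound 4 is available.

Compound 4 is therefore expected to show a modest step upward, a 2.0-fold higher number from compound 3 to compound 4 (0.30 log units; within the scatter). The estimate for compound 4 in this assay is 60 mg/kg, with a range from 25 mg/kg to 150 mg/kg.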

Compound 4, dose for half-maximal effect: 30 mg/kg
Estimate against measurement, compound 4: 2.0-fold (0.30 log units) above, within the range that was stated.
By their numbers in this assay, from the lowest: compounds 3 and 4 (each within the scatter of the next); then compounds 1 and 2 (each within the scatter of the next).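

With the acyl group held, the change from 4-methylphenyl to 4-methoxyphenyl in this assay reads as no change at the digits printed from compound 3 to compound 4 (within the scatter), so an oxygen on this aromatic carbon does not by itself raise the number. Methyl in place of the hydrogen on that oxygen gives a 3.3-fold lower number from compound 2 to compound 4 (0.52 log units; beyond the scatter), which ties the higher number of compound 2 to the free hydroxy rather than to the oxygen alone. With methoxy held, methyl in place of chloro on the acyl group gives a 3.3-fold lower number from compound 1 to compound 4 (0.52 log units; beyond the scatter), the first single-place step read on that group. Nothing measured here accounts for these steps.

From the compounds shown here alone, an amine, a carboxylic acid or a longer chain such as ethoxy on the same aromatic carbon remains open. Going by these compounds, the chloro step rests on one pair, so whether it holds with methyl or hydroxy on that carbon is also open.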